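Aryl swap on the pyrazole ring of a thiazole series

This account rests on a few compounds, and the source may have more. Where it says the series, first, only, none or still open, it means among the compounds named here.

Compound 2 `Cc1nn(-c2nc(-c3ccc(Cl)c(Cl)c3)c(SC(C)C)s2)c(C(=O)O)c1-c1cnccn1` gives the highest of the two numbers measured in a functional assay on BJAB cells (Homo sapiens) for antiproliferative activity, with a stated time of 4 days (on this read-out higher numbers stand for an effect only at larger amounts of compound and lower numbers for an effect already at smaller amounts), namely 14000 nM. For the measured compounds named here, its nearest neighbour is compound 1 `Cc1nn(-c2nc(-c3ccc(Cl)c(Cl)c3)c(SC(C)C)s2)c(C(=O)O)c1-c1cccc(Cl)c1C`, which in this assay gives 5100 nM; the only measured step, a 2.7-fold higher number from compound 1 to compound 2 (0.44 log units; beyond the scatter), bears directly on the next change. Compound 3 `CCOc1ncccc1-c1c(C)nn(-c2nc(-c3ccc(Cl)c(Cl)c3)c(SC(C)C)s2)c1C(=O)O` differs from compound 2 by 2-ethoxypyridin-3-yl in place of pyrazin-2-yl on an aromatic carbon, a larger group carrying an ethoxy arm where compound 1 also carries an ortho-type substituted ring. The estimate for compound 3 is therefore a modest gain, a 2.8-fold lower number from compound 2 to compound 3 (0.45 log units; beyond the scatter), giving an expected value of 5000 nM within a range of 2000 nM to 15000 nM.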

Compound 3, half-maximal effective concentration: 11000 nM
Beside the measured number, compound 3's estimate is 2.2-fold (0.34 log units) below it; low and high end bracket the measured number.
By their numbers in this assay, from the lowest: compound 1; then compounds 3 and 2 (each within the scatter of the next).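

In this assay, with a 1.3-fold lower number from compound 2 to compound 3 (0.10 log units; within the scatter) the exchange of pyrazin-2-yl for 2-ethoxypyridin-3-yl at this position gives no readable change, despite the added ethoxy arm. With a 2.2-fold higher number from compound 1 to compound 3 (0.33 log units; beyond the scatter) the 3-chloro-2-methylphenyl group stays apart from both nitrogen-bearing rings, and the ethoxy arm does not bring the number back to that level. Nothing available explains this grouping. As far as these compounds go, what remains open is whether an unsubstituted phenyl ring, or a pyridine carrying an amine in place of the ethoxy arm, would fall with compound 1 or with compound 2 and compound 3.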